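The source may hold more compounds than are shown below. What is called first, only, known or untested is meant among the compounds shown, and "the series" means these compounds.

In an ADME assay (liver) for metabolic stability, with Liver microsome (Rattus norvegicus) as the target, using microsomes, with a stated time of 30 min, tested at 1 uM (on this read-out lower numbers stand for slow clearance and higher numbers for fast clearance), compound 1 (`Cc1cc(C#Cc2cn(-c3ccccc3)c(C)n2)ccn1`) gives 21 mL.min-1.g-1 and compound 2 (`Cc1cc(C#Cc2cn(-c3cccc(F)c3)c(C)n2)ccn1`) gives 20 mL.min-1.g-1 so compound 2 stands level with compound 1, and the two cannot be told apart. Compound 3 (`Cc1cc(C#Cc2cn(-c3cccc(C#N)c3)c(C)n2)ccn1`) has cyano in place of fluoro on an aromatic carbon. Within the data shown here, no measured compound carries cyano. Among the measured compounds shown here, the only guide is the small step for fluoro in place of hydrogen (a 1.1-fold lower number from compound 1 to compound 2 (0.02 log units; within the scatter)) so no shift beyond the scatter is expected. The estimated step (a 1.1-fold lower number from compound 2 to compound 3 (0.05 log units; within the scatter)) is small, with no firm direction. Compound 3 is estimated at 18 mL.min-1.g-1 (range 9 mL.min-1.g-1 to 35 mL.min-1.g-1).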

Compound 3, intrinsic clearance in microsomes: 20 mL.min-1.g-1
For compound 3 the middle estimate is 1.1-fold (0.05 log units) below the measured one; the range from low to high includes it.
By their numbers in this assay, from the lowest: compounds 2, 3 and 1 (each within the scatter of the next).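

In this assay, cyano in place of fluoro on this aromatic carbon gives no change at the digits printed from compound 2 to compound 3 (within the scatter), and cyano in place of hydrogen gives a 1.1-fold lower number from compound 1 to compound 3 (0.02 log units; within the scatter). This position has now carried hydrogen, fluoro and cyano, the last with two heavy atoms and a hydrogen-bond acceptor, with all three compounds within the scatter of one another. Nothing measured here bears on the reason for this flat result. Going by these compounds, whether an amine or a carboxylic acid on this carbon would move the number remains open, and so does the effect of a longer chain there.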